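Swapping Chloro for Hydrogen and the Unbound Share

The source may report more compounds than this note shows. Statements on the series, on what has been measured and on what is new or still open speak of the compounds shown alone.

Compound 1 `CNC(=O)c1cc(C(=O)N[C@H]2CC[C@H](O)CC2)c([C@@H](C)c2cccc(Cl)c2)o1` gives 0.17
Compound 2 `CNC(=O)c1cc(C(=O)N[C@H]2[C@@H]3COC[C@@H]32)c([C@@H](C)c2ccccc2)o1` gives 0.34

In an ADME assay on blood (Rattus norvegicus, strain Wistar Han) for protein binding, read by LC-MS, using equilibrium dialysis (a higher number here means a larger unbound share of the compound, a lower number a smaller unbound share), compound 1 gives 0.17 while compound 2 gives 0.34 in the same test. These two numbers lie within the usual scatter of repeated measurements, so neither compound can be ranked against the other, and compound 1 has no clear standing of its own yet.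

The next compound to be tested is compound 3 `CNC(=O)c1cc(C(=O)N[C@H]2CC[C@H](O)CC2)c([C@@H](C)c2ccccc2)o1`, which matches compound 1 except at one place. The difference is hydrogen in place of chloro on an aromatic carbon and in plain words it is hydrogen in place of chloro on an aromatic carbon, so the 3-chlorophenyl becomes a phenyl.

For the measured compounds named here, no measured pair here shows this change on its own, so the expectation rests on the structural change alone. A modest rise in the unbound share is expected, small enough to stay close to the scatter. The estimated size of this move is a 1.6-fold higher number from compound 1 to compound 3 (0.20 log units; within the scatter) in this assay and no larger shift is foreseen. Compound 3 is therefore expected at 0.27 (estimated range 0.17 to 0.42) when measured.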

Compound 3, unbound fraction: 0.36
The estimate for compound 3 lay 1.3-fold (0.12 log units) below the measured number; low and high end bracket the measured number.
By their numbers in this assay, from the lowest: compounds 1, 2 and 3 (each within the scatter of the next, the first and the last beyond it).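

The step from chloro to hydrogen can now be read on its own: in this assay there is a 2.1-fold higher number from compound 1 to compound 3 (0.33 log units; beyond the scatter), so on this aromatic carbon, going from 3-chlorophenyl to phenyl comes with a modest rise in the unbound share that stands beyond the scatter. The group on the amide-type nitrogen behaves differently, at least for the two groups shown: with phenyl present in both compounds, the step is a 1.1-fold higher number from compound 2 to compound 3 (0.02 log units; within the scatter), so this assay does not tell these two groups apart. Nothing available explains why removing the chlorine goes with this rise.

Only chloro and hydrogen are shown on this aromatic carbon, so it remains open whether a fluoro, a methoxy or a nitrile there would give a number closer to that of compound 1 or that of compound 3. From the compounds shown here alone, it also remains open whether the chloro-to-hydrogen step would keep its size with the amide-nitrogen group of compound 2, and whether an amine or a carboxylic acid on that group would shift the unbound share.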